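Fluoro for amino on the shared core: compound 4

The source may report more compounds than this note shows. Statements on the series, on what has been measured and on what is new or still open speak of the compounds shown alone.

In a functional assay on SW-620 cells (Homo sapiens) for inhibition (a lower number here means a stronger inhibitor, a higher number a weaker inhibitor), compound 3 `CC(=O)OCCOn1cnc2c(S)nc(N)nc21` gives 4200 nM, the highest of the two numbers shown. Compound 2 `CC(=O)OC(C)n1cnc2c(Cl)nc(I)nc21` gives 3550 nM, within the scatter of compound 3. Compound 1 `CC(=O)OCCOn1cnc2c(Cl)nc(N)nc21` reports only an assay limit, > 500000 nM (the limit of > 500000 nM in this assay, at which 1 of the 3 values shown sits). For the measured compounds named here, the single measured step, an at least 110-fold lower number from compound 1 to compound 3 (2.07 log units; beyond the scatter), concerns sulfanyl in place of chloro and does not touch the change now at hand. Compound 4 `CC(=O)OCCOn1cnc2c(S)nc(F)nc21` differs from compound 3 by fluoro in place of amino on an aromatic carbon. Going by the values given here, no measured step covers fluoro in place of amino, so neither size nor direction of the change is established. The step expected, a 1.2-fold higher number from compound 3 to compound 4 (0.08 log units; within the scatter), is small, with wide uncertainty. For compound 4 the estimate in this assay is 5000 nM, with a range of 1000 nM to 30000 nM.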

Compound 4, half-maximal inhibitory concentration: > 500000 nM
Compound 4 was reported as a limit (the forecaster's own chance of this, stated with the estimate: 10%); at least 100-fold (2.00 log units) between middle value and limit.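

In this assay, sulfanyl alone does not hold the number down: with it kept, fluoro in place of amino gives an at least 110-fold higher number from compound 3 to compound 4 (2.07 log units; beyond the scatter). The group between two ring nitrogen atoms therefore matters as much as the sulfanyl in place of chloro change seen earlier, and among the compounds with one change, only compound 3 gives a measured number. Compound 4 stands at a limit of the assay, so its step has a floor but no measured size: the limit of > 500000 nM in this assay, at which 2 of the 4 values shown sit.

As far as these compounds go, whether a methylamino or hydroxyl group at this place keeps the number of compound 3 remains open. So does whether any group other than amino does.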